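Sulfonyl substituent changes in a cytotoxicity series

A few compounds are considered here, and "the series" means these few. Any claim that something is new, unique, unknown or untested is made for them only; others in the source may bear on it.

Measured so far:
compound 1 `CC(=O)OC[C@H]1O[C@H](NS(N)(=O)=O)C=C[C@@H]1OC(C)=O` gives 704000000 nM in a functional assay on A549 cells (Homo sapiens) for cytotoxicity, read by MTT assay, with a stated time of 24 h; a higher number here means a weaker inhibitor, a lower number a stronger inhibitor
compound 2 `CC(=O)OC[C@H]1O[C@H](NS(=O)(=O)c2ccc(C)cc2)C=C[C@@H]1OC(C)=O` gives 829000000 nM in this assay

Compound 2 has the highest of the two numbers in this assay; the nearest is compound 1, and that gap, a 1.2-fold higher number from compound 1 to compound 2 (0.07 log units; within the scatter), lies within the scatter. Compound 3 `CCS(=O)(=O)N[C@@H]1C=C[C@H](OC(C)=O)[C@@H](COC(C)=O)O1` differs from compound 2 by ethyl in place of 4-methylphenyl on a sulfonyl sulfur. Going by the values given here, the only step bearing on a change at the sulfonyl sulfur is a 1.2-fold higher number from compound 1 to compound 2 (0.07 log units; within the scatter), which is within the scatter, so no step beyond the scatter is expected in this assay. Compound 3 is estimated at 750000000 nM, range 300000000 nM to 1800000000 nM. The expected step is a 1.1-fold lower number from compound 2 to compound 3 (0.04 log units; within the scatter).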

Compound 3, half-maximal inhibitory concentration: 280000000 nM
The estimate for compound 3 lay 2.7-fold (0.43 log units) above the measured number; the whole stated range lies above it.
By their numbers in this assay, from the lowest: compound 3; then compounds 1 and 2 (each within the scatter of the next).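

At the sulfonyl sulfur the substituent can matter in this assay: ethyl in place of 4-methylphenyl gives a 3.0-fold lower number from compound 2 to compound 3 (0.47 log units; beyond the scatter) and ethyl in place of amino gives a 2.5-fold lower number from compound 1 to compound 3 (0.40 log units; beyond the scatter), both modest, whereas the step between amino and 4-methylphenyl stayed within the scatter. Among these three groups, only ethyl separates from the others. Nothing available explains this difference. Going by these compounds, whether a longer chain such as butyl continues the shift remains open, as does the outcome with a small alkyl group such as methyl directly on the sulfur.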